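From Isobutoxy to Butoxy on a Shared Core

The source may report more compounds than this note shows. Statements on the series, on what has been measured and on what is new or still open speak of the compounds shown alone.

Within the data shown here, in a functional assay on DLD-1 cells (Homo sapiens) for cytotoxicity, with a stated time of 48 h (a lower number here means a stronger inhibitor, a higher number a weaker inhibitor), compound 1 (`CC(C)COc1ccc2oc(/C=C/[S+](C)[O-])cc(=O)c2c1`) gives 5000 nM, the only actual number available so far. Compound 2 (`COc1cccc2oc(/C=C/[S+](C)[O-])cc(=O)c12`) is reported at > 10000 nM, which is a limit of the assay and not a number. Compound 3 (`CCCCOc1ccc2oc(/C=C/[S+](C)[O-])cc(=O)c2c1`) has not yet been measured in this assay. It keeps the core of compound 1 and differs only in the chain: propyl in place of isopropyl on a saturated chain carbon bound to an oxygen on an aromatic ring, with propyl in place of isopropyl on a saturated chain carbon bound to an oxygen on an aromatic ring, or isobutoxy to butoxy when cut one bond further out. Among the measured compounds shown here, no measured pair offers a guide to this change. The same atoms are simply joined differently, so the expected step of no change at the digits printed from compound 1 to compound 3 (within the scatter) stays within the usual scatter, in neither direction. Compound 3 is expected at 5000 nM, with an estimated range from 2000 nM to 12000 nM.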

Compound 3, half-maximal inhibitory concentration: 4800 nM
Compound 3: the middle estimate sits 1.0-fold (0.02 log units) above what was measured, and the stated range covers the measured number.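

Exchanging isopropyl for propyl on a saturated chain carbon bound to an oxygen on an aromatic ring gives, in this assay, a 1.0-fold lower number from compound 1 to compound 3 (0.02 log units; within the scatter). This is the first pair shown that differs in one place, and it shows that branching in this chain, with the same atoms joined differently, produces no step beyond the scatter. Compound 1 and compound 3 therefore cannot be ranked against each other, and the isobutoxy and butoxy chains read alike at this place.

From the compounds shown here alone, whether a longer chain or an amine at the end of the chain would move the number stays open, since this single pair speaks only for these two chains. Compound 2 adds no step, its entry being a limit of the assay and not a number: the limit of > 10000 nM in this assay, at which 1 of the 3 values shown sits.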